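Removing the ring nitrogen methyl: what to expect

The source may hold more compounds than are shown below. What is called first, only, known or untested is meant among the compounds shown, and "the series" means these compounds.

Of the compounds shown here, two have been measured in a functional assay on the whole organism (strain albino) with Rattus norvegicus as the target, read by paw edema, with stated times of 1 h and 4 h, at a dose of 25 mg/kg by the oral route; on this read-out lower numbers stand for a weaker effect and higher numbers for a stronger effect at the one dose given. Compound 1 `COc1ccc(C2CC(c3ccc(NC(=O)c4cc(Cl)ccc4OC)cc3)=NN2C)cc1` gives 88.1%. Compound 2 `COc1ccc(Cl)cc1C(=O)Nc1ccc(C2=NN(C)C(c3ccccc3[N+](=O)[O-])C2)cc1` gives 96.5% in this assay, and the step of a number 8.4 percentage points higher from compound 1 to compound 2 (within the scatter) lies within the scatter, so neither compound reads as the stronger on this evidence. Compound 3 `COc1ccc(C2CC(c3ccc(NC(=O)c4cc(Cl)ccc4OC)cc3)=NN2)cc1` differs from compound 1 by hydrogen in place of methyl on an amine nitrogen in a ring. Among the compounds with values here, the single measured step exchanges the group on the saturated ring carbon and leaves the ring nitrogen untouched, so it does not bear on this change; no measured comparison in this assay addresses the ring nitrogen at all. Without a guide in the series, the expectation for a number 4.1 percentage points lower from compound 1 to compound 3 (within the scatter) is a step of no size beyond the scatter, in either direction, with the range kept wide to reflect the missing precedent. Compound 3 is therefore estimated at 84%, between 62% and 96%.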

Compound 3, a percentage reported as activity, at one dose (the size of the read-out at that dose, not a potency): 82.6%
The estimate for compound 3 lay 1.4 percentage points above the measured number, within the range that was stated.
By their numbers in this assay, from the lowest: compounds 3, 1 and 2 (each within the scatter of the next, the first and the last beyond it).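

In this assay, within the data shown here, the first measured change at the amine nitrogen in the ring gives a number 5.5 percentage points lower from compound 1 to compound 3 (within the scatter), so hydrogen in place of methyl at this position leaves the two compounds indistinguishable. With the 4-methoxyphenyl group in place, the methyl on this nitrogen is therefore not required for a high read-out at this one dose. No available evidence accounts for this result or shows what role the nitrogen plays.

On these data alone, it remains open whether hydrogen and methyl also read alike with 2-nitrophenyl on the saturated ring carbon, and what an acetyl group or a longer chain such as propyl would give on this nitrogen. A single dose also leaves open whether compound 1 and compound 3 would separate at lower doses.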